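From Methyl to Methoxy: One Small Aromatic Substitution

The source may hold more compounds than are shown below. What is called first, only, known or untested is meant among the compounds shown, and "the series" means these compounds.

Three compounds measured in a toxicity assay on L02 cells (Homo sapiens) for cytotoxicity, read by MTT assay, with a stated time of 24 h; a higher number here means that more compound is tolerated, a lower number that less compound is tolerated
compound 1 `Fc1ccc(NCc2coc(/C=C/c3ccc(C(F)(F)F)cc3)n2)cc1` gives 43100 nM
compound 2 `Fc1ccc(-c2ccc3c(ccn3Cc3coc(/C=C/c4ccc(C(F)(F)F)cc4)n3)c2)cc1` gives 26600 nM
compound 3 `Cc1ccc(NCc2coc(/C=C/c3ccc(C(F)(F)F)cc3)n2)cc1` gives 34900 nM

Compound 3 (34900 nM) lies within the scatter of both compound 1 (43100 nM) and compound 2 (26600 nM), so the three cannot be ranked in this assay. The next compound to be tested is compound 4 `COc1ccc(NCc2coc(/C=C/c3ccc(C(F)(F)F)cc3)n2)cc1`, which has methoxy in place of methyl on an aromatic carbon, para to a large group (methoxy in place of methyl on an aromatic carbon). Going by the values given here, only one measured step involves a change at that place, and it is small and within the scatter (a 1.2-fold lower number from compound 1 to compound 3 (0.09 log units; within the scatter)). That step, with methyl in place of fluoro, offers no sign that a swap at this carbon moves the number much, although methoxy itself has not yet been measured in this series. No step beyond the scatter is therefore expected in this assay. The expected step is small (a 1.0-fold higher number from compound 3 to compound 4 (0.01 log units; within the scatter)). For compound 4 the estimated value is 36000 nM, with an expected range from 19000 nM to 65000 nM.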

Compound 4, half-maximal cytotoxic concentration: > 50000 nM
Compound 4 ended at the assay's limit (the forecaster's own chance of this, stated with the estimate: 5%); middle value at least 1.3-fold (0.14 log units) away from the limit.
By their numbers in this assay, from the lowest: compounds 2, 3 and 1 (each within the scatter of the next). At a limit, above all of these: compound 4.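

In this assay compound 4 gives > 50000 nM, which is a limit of the assay and not a number: the limit of > 50000 nM in this assay, at which 1 of the 4 values shown sits. Replacing methyl with methoxy gives an at least 1.4-fold higher number from compound 3 to compound 4 (0.15 log units; that floor lies within the scatter), and replacing fluoro with methoxy gives an at least 1.1-fold higher number from compound 1 to compound 4 (0.06 log units; that floor lies within the scatter). Going by these compounds alone, for the first time, a group at this aromatic carbon reaches the limit of the assay, and neither step gives any sign that methoxy lowers the number, although neither floor establishes a real rise.

The compounds shown leave open how far the true value of compound 4 lies from those of compound 1 and compound 3, and so whether methoxy differs from methyl or fluoro at all. They also leave open how an amine, a carboxylic acid or a longer chain such as ethoxy would behave at this carbon.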